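The source may report more compounds than this note shows. Statements on the series, on what has been measured and on what is new or still open speak of the compounds shown alone.

Measured compounds:
- compound 1 `CCCCCCCCCCCCn1nnc(C(C(=O)Nc2ccc(F)cc2F)c2ccccc2)n1` — in an assay on isolated protein for inhibition of sterol O-acyltransferase 1 (Mus musculus), tested at 0.1 uM (on this read-out lower numbers stand for less inhibition and higher numbers for more inhibition at the one concentration tested (going by the name of the read-out)), compound 1 gives 1%
- compound 2 `CCCCCCCCCCCCn1nnc(C(C(=O)Nc2c(C)nn(C)c2C)c2ccccc2)n1` — compound 2 gives 66%
- compound 3 `CCCCCCCCCCCCn1nnc(C(C(=O)Nc2c(OC)cc(OC)cc2OC)c2ccc(N(C)C)cc2)n1` — compound 3 gives 0%

Compound 3 holds the lowest of the three numbers, but its gap to compound 1 lies within the scatter, so the two cannot be ordered; only compound 2 stands apart from it, beyond the scatter. Going by the values given here, the one step on record, a number 65 percentage points higher from compound 1 to compound 2 (beyond the scatter), concerns the group on the amide-type nitrogen and shows how strongly that position can move the read-out.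

Compound 4 `CCCCCCCCCCCCn1nnc(C(C(=O)Nc2c(OC)cc(OC)cc2OC)c2ccccn2)n1` keeps the 2,4,6-trimethoxyphenyl amide of compound 3 and alters a different place: pyridin-2-yl in place of 4-(dimethylamino)phenyl on a saturated chain carbon bound to an aromatic carbon and a carbonyl carbon. Among the compounds with values here, no measured pair changes this position, so the step from compound 3 to compound 4 has no direct precedent. The group on the amide-type nitrogen, which the recorded step shows to matter, is unchanged, and compound 3 with that group sits at the floor of the read-out. A modest rise at most is expected, a number 10 percentage points higher from compound 3 to compound 4 (within the scatter), with a step beyond the scatter judged unlikely. Compound 4 is therefore estimated at 10%, ranging from 0% to 35%, in this assay.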

Compound 4, a percentage reported as inhibition, at one concentration (the size of the read-out at that concentration, not a potency): 23%
Beside the measured number, compound 4's estimate is 13 percentage points below it, and the stated range covers the measured number.
By their numbers in this assay, from the lowest: compounds 3 and 1 (each within the scatter of the next); then compound 4; then compound 2.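

In this assay, the saturated chain carbon bound to an aromatic carbon and a carbonyl carbon now has a step of its own: pyridin-2-yl in place of 4-(dimethylamino)phenyl gives a number 23 percentage points higher from compound 3 to compound 4 (beyond the scatter), so the read-out responds at this position as well as on the amide-type nitrogen, the only place covered by the earlier step. With the 2,4,6-trimethoxyphenyl amide unchanged across this step, that amide does not by itself hold a compound at the floor of the read-out. No measurement on record bears on what lies behind the step.

As far as these compounds go, whether pyridin-2-yl would also raise the number with the 1,3,5-trimethyl-1H-pyrazol-4-yl amide of compound 2, which gives 66%, remains open. Also open, from the compounds shown here alone, are how a carboxylic acid or a morpholine ring would fare at this position, and whether the step follows the nitrogen entering the aromatic ring or the departure of the dimethylamino group, two changes that this single pair cannot separate.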